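A few compounds are considered here, and "the series" means these few. Any claim that something is new, unique, unknown or untested is made for them only; others in the source may bear on it.

In an ADME assay on HCT-116 cells (Homo sapiens) for cytotoxicity, read by CellTiter-Glo, with a stated time of 72 h (on this read-out higher numbers stand for weaker inhibition and lower numbers for stronger inhibition), compound 1 (`CCCC(=O)N(Cc1ccccc1)C1CCN(S(=O)(=O)c2c(C)cc(C)cc2C)CC1`) gives > 5000 nM as its reading, a limit of the assay and not a number. Compound 2 (`COc1ccccc1-c1ccc(S(=O)(=O)N2CCC(N3CCC(C)CC3)CC2)cc1`) gives > 5000 nM as its reading, also only a limit. Within the data shown here, compound 2 therefore stands with compound 1 at the limit of > 5000 nM in this assay, at which 2 of the 2 values shown sit, and has no exact value, and no step between measured compounds is available to scale a change.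

Compound 3 (`CC1CCN(C2CCN(S(=O)(=O)c3ccc(-c4ccccc4)cc3)CC2)CC1`) differs from compound 2 in one place, with hydrogen in place of methoxy on an aromatic carbon, ortho to a large group, so that 2-methoxyphenyl becomes phenyl (hydrogen in place of methoxy on an aromatic carbon). The shared core stays the same.

Among the measured compounds shown here, the only guide in this assay is that neither measured compound reaches a number, so no movement in either direction beyond the scatter is expected. The estimated change a step that the limit leaves unreadable from compound 2 to compound 3 is expected to stay within that scatter. Compound 3 is estimated at 6000 nM in this assay, with an expected range from 2500 nM to 15000 nM and a strong chance that only a limit is reported.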

Compound 3, half-maximal inhibitory concentration: > 5000 nM
Compound 3: no number, only a limit; the forecaster's own chance of this, stated with the estimate: 80%; the middle value is on the limit's open side.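

Compound 2 and compound 3 both give only a limit in this assay, so no step can be read for the change from 2-methoxyphenyl to phenyl: the limit of > 5000 nM in this assay, at which 3 of the 3 values shown sit.

The compounds shown leave open whether any member of this series gives an exact value in this assay, and what size the exchange of methoxy for hydrogen has there.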